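Shortening the sulfonyl chain on the shared core

The compounds below may be only part of what the source reports. "The series", "measured", "known", "first", "only" and "open" are said of these compounds alone.

Compound 1 `CCCS(=O)(=O)Nc1cccc2c1CCC2c1ncc[nH]1` carries a (propylsulfonyl)amino group on an aromatic carbon of the shared core. In a functional assay on CHO cells for agonist activity at Alpha-1D adrenergic receptor (Homo sapiens), read by FLIPR and calcium flux (on this read-out lower numbers stand for an effect already at smaller amounts and higher numbers for an effect only at larger amounts of compound), compound 1 gives > 10000 nM, which is a limit of the assay and not a number. Compound 2 `CS(=O)(=O)Nc1cccc2c1CCCC2c1ncc[nH]1` belongs to the same series with a different core. In this assay compound 2 gives > 10000 nM; > 10000 nM; > 10000 nM (3 entries), every entry a limit. Compound 3 `Cn1cc(-c2cccc3c2CCC3c2ncc[nH]2)cn1` has 1-methyl-1H-pyrazol-4-yl in place of (propylsulfonyl)amino on the aromatic carbon. In this assay compound 3 gives > 10000 nM, again a limit. The step that the two limits leave unreadable from compound 1 to compound 3 cannot be read in size or direction, since both ends sit at the limit of > 10000 nM in this assay, at which 2 of the 3 values shown sit.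

Compound 4 `CCS(=O)(=O)Nc1cccc2c1CCC2c1ncc[nH]1` is still to be measured; it differs from compound 1 by hydrogen in place of methyl on a saturated chain carbon, two bonds along the chain from a sulfonyl sulfur. No measured step resembles this change: the only step shown, from compound 1 to compound 3, is unreadable, and every value in the series is a limit. Nothing shown supports an expected move beyond the scatter in this assay, so the expected step that the limit leaves unreadable from compound 1 to compound 4 is none beyond the scatter. In this assay compound 4 is estimated at 15000 nM, with a range from 5000 nM to 50000 nM, and most probably it is reported only as a limit.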

Compound 4, half-maximal effective concentration: > 10000 nM
Compound 4: a limit, no number; the forecaster's own chance of this, stated with the estimate: 85%; the middle value does not contradict the limit.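

In this assay compound 4 gives > 10000 nM, a limit and not a number. No new step can be read from compound 1 or compound 3 to compound 4, as the values rest on the same limit: the limit of > 10000 nM in this assay, at which 3 of the 4 values shown sit. The compounds shown leave open whether changing the sulfonyl chain or the group on the aromatic carbon affects this read-out at all.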